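The compounds below may be only part of what the source reports. "The series", "measured", "known", "first", "only" and "open" are said of these compounds alone.

Compound 2, `CCC(C)COc1cccc2ccc(N)nc12`: 36 nM
Compound 1, `CC(CC(C)(C)C)Oc1cccc2cccnc12`: a limit, > 2000 nM
Compound 3, `CC(CC(C)(C)C)Oc1cccc2ccc(N3CCCC3)nc12`: a limit, > 2000 nM

Going by the values given here, in an assay on cells with melanin-concentrating hormone receptor 1 (Homo sapiens) as the target, read by radioligand binding (a lower number here means a stronger inhibitor, a higher number a weaker inhibitor), compound 2 gives the only number among the three measured compounds; the two other values are limits. For compound 1 the value > 2000 nM is a limit of the assay and not a number. For compound 3 the value > 2000 nM is likewise a limit. Among the compounds with values here, the one step between measured compounds that differ in a single place, a step that the two limits leave unreadable from compound 1 to compound 3, runs from one limit to another, and its size cannot be read. the limit of > 2000 nM in this assay, at which 2 of the 3 values shown sit, marks where two of the three values sit, so the measured steps give no calibrated size at all.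

Compound 4, `CC(C)=CCOc1cccc2ccc(N)nc12`, differs from compound 2 by 2-methylprop-1-en-1-yl in place of sec-butyl on a saturated chain carbon bound to an oxygen on an aromatic ring. Within the data shown here, no measured step bears on this change: the chains of compound 1 and compound 3 are not those of compound 2 or compound 4, and the single measured step is unreadable. The change keeps the count of heavy atoms and adds one double bond outside aromatic rings, so the step of a 1.5-fold higher number from compound 2 to compound 4 (0.18 log units; within the scatter) is expected to stay within the usual scatter of this assay. Compound 4 is estimated at 55 nM, with a range from 18 nM to 220 nM.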

Compound 4, half-maximal inhibitory concentration: > 2000 nM
Compound 4: a limit, no number (the forecaster's own chance of this, stated with the estimate: 5%); middle value at least 36-fold (1.56 log units) from the limit.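

In this assay compound 4 gives > 2000 nM, which is a limit of the assay and not a number. Going by these compounds alone, on a saturated chain carbon bound to an oxygen on an aromatic ring, 2-methylprop-1-en-1-yl in place of sec-butyl gives the only readable step, an at least 55-fold higher number from compound 2 to compound 4 (1.74 log units; beyond the scatter), so this place is sensitive to the chain even though both groups hold 4 heavy atoms and the counted difference is 1 double bond outside aromatic rings. The step has a lower bound but no upper one, and the limit now holds most of the set: the limit of > 2000 nM in this assay, at which 3 of the 4 values shown sit.

The compounds shown leave open whether the double bond itself or the altered branching of the chain goes with the loss, a question that a saturated 3-methylbutyl chain on the same oxygen would separate from the 3-methylbut-2-en-1-yl chain of compound 4. They also leave open how far a longer chain or a cyclopropylmethyl group at this place would stay near compound 2, at 36 nM.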